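From Fluorophenyl to Ethoxyphenylamino on the Shared Core

This account rests on a few compounds, and the source may have more. Where it says the series, first, only, none or still open, it means among the compounds named here.

Measured so far:
- compound 1, `COc1cc(C(=O)c2sc3ccccc3c2-c2ccc(F)cc2)cc(OC)c1OC`: 3200 nM
- compound 2, `COc1cc(C(=O)c2sc3ccccc3c2-c2ccc(SC)cc2)cc(OC)c1OC`: 1300 nM

In a functional assay on HL-60 cells (Homo sapiens) for antiproliferative activity, read by MTT assay, with a stated time of 72 h (on this read-out higher numbers stand for weaker inhibition and lower numbers for stronger inhibition), compound 1 gives the highest of the two numbers shown; its nearest neighbour is compound 2, reached by the step of a 2.5-fold lower number from compound 1 to compound 2 (0.39 log units; beyond the scatter). The new compound 3, `CCOc1ccc(Nc2c(C(=O)c3cc(OC)c(OC)c(OC)c3)sc3ccccc23)cc1`, differs from compound 1 in one place: (4-ethoxyphenyl)amino in place of 4-fluorophenyl on an aromatic carbon. Within the data shown here, no measured step swaps the whole group at this position for a nitrogen-linked one, so the only guide is the step from compound 1 to compound 2, where a larger para group gave a modest gain. A step of similar size is therefore expected, toward a lower number, though with wide uncertainty. For compound 3 the estimate is 1500 nM, within 300 nM to 8000 nM, which means an expected step of a 2.1-fold lower number from compound 1 to compound 3 (0.33 log units; beyond the scatter).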

Compound 3, half-maximal inhibitory concentration: 500 nM
Beside the measured number, compound 3's estimate is 3.0-fold (0.48 log units) above it; the range from low to high includes it.
By their numbers in this assay, from the lowest: compound 3; then compound 2; then compound 1.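

In this assay, placing (4-ethoxyphenyl)amino on this aromatic carbon instead of 4-fluorophenyl gives a 6.4-fold lower number from compound 1 to compound 3 (0.81 log units; beyond the scatter), so this position accepts a benzene ring joined to the shared core through a nitrogen, and the result is better than with the directly joined ring of compound 1. Placing the same group here instead of 4-(methylsulfanyl)phenyl gives a 2.6-fold lower number from compound 2 to compound 3 (0.41 log units; beyond the scatter), so the new group also improves on the better of the two earlier compounds. No measurement on hand explains this gain.

On these data alone, this change brings in the nitrogen link and the ethoxy group together, so the share of each remains open. A (4-fluorophenyl)amino group would separate the two, while a propoxy chain or a dimethylamino group in place of ethoxy would test how much further change this position accepts.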